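From oxolan-3-yl to 4-(trifluoromethyl)cyclohexyl

The source may hold more compounds than are shown below. What is called first, only, known or untested is meant among the compounds shown, and "the series" means these compounds.

Within the data shown here, in a physicochemical assay for solubility, using the shake flask method, in phosphate buffer, measured as kinetic solubility, with a stated time of 20 h, at pH 6.5 (on this read-out higher numbers stand for higher solubility and lower numbers for lower solubility), compound 3 (`FC(F)(F)c1ccc(Nc2cc3[nH]c(C4CCOC4)nc3cn2)nc1`) gives 166000 nM and this is the only true number so far. Compound 1 (`COc1cccnc1Nc1cc2[nH]c(-c3cccc(C(F)(F)F)c3)nc2cn1`) gives < 5000 nM as a limit of the assay and not as a number. Compound 2 (`FC(F)(F)c1cccc(-c2nc3cnc(Nc4cccnn4)cc3[nH]2)c1`) also gives < 5000 nM as a limit of the assay and not as a number. Among the measured compounds shown here, the only measured step is a step that the two limits leave unreadable from compound 1 to compound 2 and it offers no size to carry over.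

Compound 4 (`FC(F)(F)c1ccc(Nc2cc3[nH]c([C@H]4CC[C@H](C(F)(F)F)CC4)nc3cn2)nc1`) takes 4-(trifluoromethyl)cyclohexyl in place of oxolan-3-yl on an aromatic carbon of compound 3 (4-(trifluoromethyl)cyclohexyl in place of oxolan-3-yl on an aromatic carbon). For the measured compounds named here, no measured step covers this change, so the guide is indirect. A downward step beyond the scatter is nevertheless expected in this assay for this pair. That expectation rests on the limit of < 5000 nM in this assay, at which 2 of the 3 values shown sit, and on the fact that neither compound 1 nor compound 2 carries oxolan-3-yl, although both also differ from compound 3 elsewhere. The estimated change is a 28-fold lower number from compound 3 to compound 4 (1.44 log units; beyond the scatter) and its size is uncertain. Compound 4 is estimated at 6000 nM with an expected range from 1500 nM to 30000 nM. Compound 4 may well turn out to give only a limit of the assay.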

Compound 4, solubility: < 5000 nM
Compound 4 ended at the assay's limit; the forecaster's own chance of this, stated with the estimate: 55%; middle value at least 1.2-fold (0.07 log units) from the limit.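

Among these compounds, with the rest of the structure held constant, the change on an aromatic carbon of the five-membered aromatic ring with 2 nitrogen gives the first readable step, and it is large and beyond the scatter: an at least 33-fold lower number from compound 3 to compound 4 (1.52 log units; beyond the scatter). In this assay compound 4 gives < 5000 nM, which is a limit of the assay and not a number, so the step marks only the smallest size the data allow for this change. The result also shows that the single true number in the series now rests with oxolan-3-yl at this position, while the read-out offers little room at its lower end: the limit of < 5000 nM in this assay, at which 3 of the 4 values shown sit.

The compounds shown leave open how far the step goes past the limit, and whether it follows from the exchange of the ring itself or from the trifluoromethyl group that the new ring carries. A plain cyclohexyl at this place would separate those two parts of the change, and a cyclohexyl bearing an amine or a carboxylic acid in place of the trifluoromethyl would show how this position reads with such a group.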